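A few compounds are considered here, and "the series" means these few. Any claim that something is new, unique, unknown or untested is made for them only; others in the source may bear on it.

Working notes on the series.

Going by the values given here, in an assay for inhibition of Nicotinamide phosphoribosyltransferase (Homo sapiens), read by mass spectrometry, with stated times of 15 min and 30 min (on this read-out lower numbers stand for stronger inhibition and higher numbers for weaker inhibition), compound 2 `O=C(NCc1ccc(S(=O)(=O)N2CCCCC2)cc1)c1ccc2nc[nH]c2c1` gives 310 nM, the higher of the two numbers measured so far. Among the compounds with values here, the only other measured compound is compound 1 `O=C(NCc1ccc(S(=O)(=O)N2CCCCC2)cc1)c1cc2cnccc2s1`, which in this assay gives 150 nM; the change a 2.1-fold higher number from compound 1 to compound 2 (0.32 log units; beyond the scatter).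

Compound 3 `O=C(NCc1ccc(S(=O)(=O)N2CCCCC2)cc1)c1cc2ccncc2o1` has not yet been measured. It differs from compound 2 in that (a group of 9 heavy atoms (7 carbon, 1 nitrogen, 1 oxygen; one five-membered aromatic ring with 1 hetero atom, one six-membered aromatic ring with 1 hetero atom) in place of a group of 9 heavy atoms (7 carbon, 2 nitrogen; one five-membered aromatic ring with 2 hetero atoms, one six-membered aromatic ring of carbon only), on a carbonyl carbon). The group that enters has, like the group in compound 1, one five-membered aromatic ring with one hetero atom and one six-membered aromatic ring with one hetero atom, while the 1H-benzimidazol-6-yl group that leaves is the one whose introduction produced the step of a 2.1-fold higher number from compound 1 to compound 2 (0.32 log units; beyond the scatter). That single step is the only measured one that bears on the change, and its size was modest. The expectation for compound 3 in this assay is therefore a modest step back in the lowering direction, roughly undoing the change seen from compound 1 to compound 2, although the oxygen in the entering group is not the sulfur of compound 1, so the return may be incomplete. The estimated step is a 1.7-fold lower number from compound 2 to compound 3 (0.24 log units; within the scatter). Compound 3 is expected to give about 180 nM in this assay, with a range from 70 nM to 450 nM.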

Compound 3, half-maximal inhibitory concentration: 40 nM
For compound 3 the middle estimate is 4.5-fold (0.65 log units) above the measured one, and the stated range ends above it.
By their numbers in this assay, from the lowest: compound 3; then compound 1; then compound 2.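

In this assay, going by these compounds alone, the position on the carbonyl carbon proves more sensitive than the one earlier step suggested: the change from the 1H-benzimidazol-6-yl group to the group of compound 3 gives a 7.8-fold lower number from compound 2 to compound 3 (0.89 log units; beyond the scatter), which takes the series past the number of compound 1 and does not merely return to it. The comparison within the pair with matching ring counts gives a 3.8-fold lower number from compound 1 to compound 3 (0.57 log units; beyond the scatter), so groups with one five-membered aromatic ring with one hetero atom and one six-membered aromatic ring with one hetero atom are not interchangeable here, and compound 3 now has the lowest number of the three, with its steps to both others beyond the scatter. No measurement at hand accounts for the size of either step.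

Oxygen in place of sulfur is not the only difference between these two groups, since the ring nitrogen also stands differently in their structures, so the three compounds cannot separate those two contributions. Also open, going by these compounds, are the part played by the ring nitrogen itself, which a benzofuran-2-yl group would test, and whether the same order holds with a morpholine in place of the piperidine.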